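Sulfur-bearing vinyl substituents on the shared core

The compounds below may be only part of what the source reports. "The series", "measured", "known", "first", "only" and "open" are said of these compounds alone.

Measured so far in an assay for inhibition of Fatty-acid amide hydrolase 1 (Rattus norvegicus), using a Dixon plot; on this read-out lower numbers stand for stronger inhibition and higher numbers for weaker inhibition:
compound 1 `O=Cc1ccc(-c2cnc(C(=O)CCCCCCc3ccccc3)o2)nc1`: 2.2 nM
compound 2 `O=C(CCCCCCc1ccccc1)c1ncc(-c2ccc(CCl)cn2)o1`: 22.4 nM
compound 3 `CCOS(=O)(=O)/C=C/c1ccc(-c2cnc(C(=O)CCCCCCc3ccccc3)o2)nc1`: 2.1 nM

Compound 3 gives the lowest number of the three, though the gap to compound 1 is within the scatter; only compound 2 stands clearly apart, as an 11-fold lower number from compound 2 to compound 3 (1.03 log units; beyond the scatter) shows. The step of a 1.0-fold lower number from compound 1 to compound 3 (0.02 log units; within the scatter) indicates that formyl and the longer 2-(ethoxysulfonyl)ethenyl group are tolerated alike, whereas a 10-fold higher number from compound 1 to compound 2 (1.01 log units; beyond the scatter) marks chloromethyl as the outlier.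

Compound 4 `C[S+]([O-])/C=C/c1ccc(-c2cnc(C(=O)CCCCCCc3ccccc3)o2)nc1` carries the change (a group of 3 heavy atoms (1 carbon, 1 oxygen, 1 sulfur; no ring) in place of a group of 6 heavy atoms (2 carbon, 3 oxygen, 1 sulfur; no ring), on a double-bonded chain carbon bound to a double-bonded chain carbon). For the measured compounds named here, no measured step alters that chain end while keeping the ethenyl link, so the prior steps bear only indirectly. Given that compound 1 and compound 3 sit together, little movement is expected: a 1.7-fold higher number from compound 3 to compound 4 (0.22 log units; within the scatter). Compound 4 is estimated at 3.5 nM, in the range 1 nM to 12 nM.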

Compound 4, inhibition constant: 3 nM
Beside the measured number, compound 4's estimate is 1.2-fold (0.07 log units) above it; the measured number falls inside the stated range.
By their numbers in this assay, from the lowest: compounds 3, 1 and 4 (each within the scatter of the next); then compound 2.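

In this assay, swapping the ethoxysulfonyl end for the smaller sulfur-bearing group on the ethenyl link leaves the number within the scatter (a 1.4-fold higher number from compound 3 to compound 4 (0.15 log units; within the scatter)), so this chain end accepts both groups alike. The same holds against formyl on the aromatic carbon (a 1.4-fold higher number from compound 1 to compound 4 (0.13 log units; within the scatter)), while chloromethyl stays apart (a 7.5-fold lower number from compound 2 to compound 4 (0.87 log units; beyond the scatter)). No evidence here gives a cause for these steps.

From the compounds shown here alone, whether an amine or a carboxylic acid at this chain end would fit equally well remains open. So does the role of the ethenyl link itself.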